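Compound 4: Pyridin-4-yl in Place of 3-Methoxyphenyl

This account rests on a few compounds, and the source may have more. Where it says the series, first, only, none or still open, it means among the compounds named here.

Compound 3 `COc1cccc(/C=N/NC(=O)c2cccnc2Nc2cccc(C(F)(F)F)c2)c1` gives 52.8% in a functional assay on the whole organism (strain Wistar) for inhibition, with Rattus norvegicus as the target, read by paw edema, with a stated time of 30 min, at a dose of 10 mg/kg by the intraperitoneal route (on this read-out lower numbers stand for less inhibition and higher numbers for more inhibition at the one dose given (going by the name of the read-out)), the second highest of the three measured numbers. Compound 2 `O=C(N/N=C/c1cccc(O)c1)c1cccnc1Nc1cccc(C(F)(F)F)c1` reaches 67.5%, and compound 1 `O=C(N/N=C/c1ccc(F)cc1)c1cccnc1Nc1cccc(C(F)(F)F)c1` gives 33.9%; the two steps of a number 18.9 percentage points higher from compound 1 to compound 3 (beyond the scatter) and a number 14.7 percentage points lower from compound 2 to compound 3 (beyond the scatter) set the measured range. Compound 4 `O=C(N/N=C/c1ccncc1)c1cccnc1Nc1cccc(C(F)(F)F)c1` differs from compound 3 in one place: pyridin-4-yl in place of 3-methoxyphenyl on a carbon with a double bond to nitrogen. Among the compounds with values here, no measured step bears directly on this change; the counted hydrogen-bond acceptors stay the same, while the steps of a number 33.6 percentage points higher from compound 1 to compound 2 (beyond the scatter) and a number 14.7 percentage points lower from compound 2 to compound 3 (beyond the scatter) show that the group on this carbon can shift the read-out by modest to large amounts. The expected step of a number 7.8 percentage points lower from compound 3 to compound 4 (within the scatter) is small and may fall within the scatter. Compound 4 is therefore estimated at 45%, between 25% and 65%.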

Compound 4, a percentage reported as inhibition, in the whole organism at one dose (the size of the read-out at that dose, not a potency): 68.1%
Compound 4: middle estimate off by 23.1 percentage points, on the low side; measured number above the stated range.
By their numbers in this assay, from the lowest: compound 1; then compound 3; then compounds 2 and 4 (each within the scatter of the next).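

In this assay pyridin-4-yl on the carbon with a double bond to nitrogen gives a number 15.3 percentage points higher from compound 3 to compound 4 (beyond the scatter) and a number 34.2 percentage points higher from compound 1 to compound 4 (beyond the scatter) as its steps, while a number 0.6 percentage points higher from compound 2 to compound 4 (within the scatter) sets it level with 3-hydroxyphenyl. A high number at this place therefore does not depend on a hydroxyl group, which compound 4 lacks. The compounds shown leave open how a phenyl ring carrying an amine or a carboxylic acid would read here. Nothing shown gives a measured reason for any of these steps.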